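This account rests on a few compounds, and the source may have more. Where it says the series, first, only, none or still open, it means among the compounds named here.

Compound 1 `O=C1NC(=O)/C(=C/c2ccc(OCc3csc(-c4ccccc4)n3)cc2)S1` gives 40.3% in a functional assay on the whole organism (strain Wistar) with Rattus norvegicus as the target, with a stated time of 15 days, at a dose of 30 mg/kg by the oral route; a lower number here means a weaker effect, a higher number a stronger effect of the compound at the dose given.
Compound 2 `O=C1NC(=O)/C(=C/c2ccc(OCCSc3nnc(Cc4ccccc4)[nH]3)cc2)S1` gives 38.3% in this assay.
Compound 3 `Cc1ccc(-c2nnc(SCCOc3ccc(/C=C4\SC(=O)NC4=O)cc3)[nH]2)cc1` gives 40.3% in this assay.

Compound 3 stands level with compound 1 in this assay, the two together being the highest of the three numbers, while the gap to compound 2 lies within the scatter. The one measured step among these compounds, a number 2 percentage points higher from compound 2 to compound 3 (within the scatter), came from a 4-methylphenyl in place of benzyl on an aromatic carbon and stayed within the scatter.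

Compound 4 `O=C1NC(=O)/C(=C/c2ccc(OCCSc3nnc(-c4ccc(Cl)cc4)[nH]3)cc2)S1` has yet to be measured. It differs from compound 3 by chloro in place of methyl on an aromatic carbon. For the measured compounds named here, no measured step exchanges one substituent of the 4-methylphenyl for another, so nothing bears directly on this change. Going by the values given here, the only step available, a number 2 percentage points higher from compound 2 to compound 3 (within the scatter), altered the same part of the molecule more deeply and still moved the read-out by less than the scatter. Across all three measured compounds, differing widely in the linker and in the aromatic group, the activity in this assay stays within a narrow band.

Compound 4 is therefore expected to give a step of a number 0.3 percentage points lower from compound 3 to compound 4 (within the scatter), that is, no change beyond the scatter. Compound 4 is estimated at 40%, within a range from 30% to 50%.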

Compound 4, a percentage reported as activity, at one dose (the size of the read-out at that dose, not a potency): 32.9%
Compound 4: the middle estimate sits 7.1 percentage points above what was measured; the measured number falls inside the stated range.
By their numbers in this assay, from the lowest: compounds 4, 2, 1 and 3 (each within the scatter of the next).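

With chloro in place of methyl on the aromatic carbon para to a large group, the series now has its first exchange of one substituent for another at this place, and in this assay that exchange gives a number 7.4 percentage points lower from compound 3 to compound 4 (within the scatter). The wider change of 4-chlorophenyl in place of benzyl gives a number 5.4 percentage points lower from compound 2 to compound 4 (within the scatter), so neither the substituent nor the form of the aromatic group separates these compounds beyond the scatter at the single dose tested. Nothing available accounts for these numbers.

The compounds shown leave open whether another group at this place, such as methoxy, an amine or a carboxylic acid, would move the read-out beyond the scatter, since methyl and chloro are the only substituents seen there. They also leave open whether a longer chain in place of the linker shared by compound 2, compound 3 and compound 4 would do so, and whether the same steps would hold at another dose.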